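Moving the chlorine on the benzyl arm of a triazole

The compounds below may be only part of what the source reports. "The series", "measured", "known", "first", "only" and "open" are said of these compounds alone.

Compound 1 `O=c1ccoc2cc(OCc3cn(Cc4cccc(F)c4)nn3)ccc12` gives > 100000 nM in a functional assay on SW480 cells (Homo sapiens) for cytotoxicity, read by MTT assay, with a stated time of 48 h; a lower number here means a stronger inhibitor, a higher number a weaker inhibitor; that value is a limit of the assay. Compound 2 `O=c1ccoc2cc(OCc3cn(Cc4ccccc4Br)nn3)ccc12` gives > 100000 nM in this assay, again a limit. For the measured compounds named here, compound 3 `O=c1ccoc2cc(OCc3cn(Cc4ccccc4Cl)nn3)ccc12` gives 23500 nM in this assay, the only plain number among the three.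

Compound 3 thus stands alone with a measured value, the two others sitting at the limit of > 100000 nM in this assay, at which 2 of the 3 values shown sit. The steps to it read an at least 4.2-fold lower number from compound 1 to compound 3 (0.62 log units; beyond the scatter) and an at least 4.2-fold lower number from compound 2 to compound 3 (0.62 log units; beyond the scatter), while the pair of compounds 1 and 2 gives a step that the two limits leave unreadable from compound 1 to compound 2.

Compound 4 `O=c1ccoc2cc(OCc3cn(Cc4ccc(Cl)cc4)nn3)ccc12` differs from compound 3 by 4-chlorophenyl in place of 2-chlorophenyl on a saturated chain carbon bound to an aromatic nitrogen. Going by the values given here, no measured step moves the chlorine around the ring, so the direction is open. Compound 4 is expected to give 45000 nM, between 15000 nM and 150000 nM, a step of a 1.9-fold higher number from compound 3 to compound 4 (0.28 log units; within the scatter) that is estimated to lie near the edge of the scatter.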

Compound 4, half-maximal inhibitory concentration: > 100000 nM
Compound 4 gave a limit, no number; the forecaster's own chance of this, stated with the estimate: 40%; at least 2.2-fold (0.34 log units) between middle value and limit.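

With the atoms unchanged, 4-chlorophenyl in place of 2-chlorophenyl gives, in this assay, an at least 4.2-fold higher number from compound 3 to compound 4 (0.62 log units; beyond the scatter). Among these compounds, then, a chlorine on the ring does not by itself give a plain number; what differs between compound 3 and compound 4 is only how the same atoms are joined. The steps among compound 1, compound 2 and compound 4 cannot be read, and compound 3 remains the only plain number: the limit of > 100000 nM in this assay, at which 3 of the 4 values shown sit.

As far as these compounds go, how far the true value of compound 4 lies past its limit stays open. So does whether an amine or a carboxylic acid in place of the chlorine would give a plain number.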